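Stereochemical inversion on the methylcyclopropyl amide

This account rests on a few compounds, and the source may have more. Where it says the series, first, only, none or still open, it means among the compounds named here.

Compound 1 `CCCC(=O)N1CC2CC(C1)N2` gives 110% in an assay on SH-EP1 cells for agonist activity at Neuronal acetylcholine receptor; alpha4/beta2 (Homo sapiens), read by FLIPR and calcium flux; on this read-out higher numbers stand for larger maximal responses and lower numbers for smaller maximal responses. Compound 2 `O=C([C@@H]1C[C@H]1F)N1CC2CC(C1)N2` gives 110% in this assay. Compound 3 `C[C@@H]1C[C@@H]1C(=O)N1CC2CC(C1)N2` gives 97% in this assay, the lowest of the three measured numbers. The step of a number 13 percentage points lower from compound 1 to compound 3 (beyond the scatter) and the step of a number 13 percentage points lower from compound 2 to compound 3 (beyond the scatter) both place it below the other two, whereas no change at the digits printed from compound 1 to compound 2 (within the scatter).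

Compound 4 `C[C@H]1C[C@@H]1C(=O)N1CC2CC(C1)N2` is the next compound to be measured in this assay. It differs from compound 3 as follows: the two compounds have the same atoms and bonds; at least one stereo element is drawn with a configuration in one of them and without one in the other: 1 of 4 stereo elements differ; a stereocentre at a saturated ring carbon is drawn R in compound 3 and S in compound 4. Within the data shown here, no measured step consists of a change of configuration alone; the two steps that reach compound 3 exchange the group on the carbonyl carbon and were modest in size. A flip of one stereocentre in a group that already sits somewhat below compound 1 could move the number in either direction, so the expected step of a number 3 percentage points higher from compound 3 to compound 4 (within the scatter) is small, with a range widened to cover both directions. Compound 4 is therefore estimated at 100% in this assay, between 82% and 118%.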

Compound 4, largest response reached (Emax), in percent of the reference or control that the assay uses: 85%
Estimate against measurement, compound 4: 15 percentage points above; the range from low to high includes it.
By their numbers in this assay, from the lowest: compound 4; then compound 3; then compounds 1 and 2 (each within the scatter of the next).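

Among these compounds, the 2-methylcyclopropyl group is sensitive to configuration: a change at one saturated ring carbon, with atoms and bonds unchanged, gives a number 12 percentage points lower from compound 3 to compound 4 (beyond the scatter) in this assay, a step as large as the one that separated compound 3 from the propyl amide. Among the compounds shown here, the same configuration also widens the gap to the other groups on the carbonyl carbon, giving a number 25 percentage points lower from compound 1 to compound 4 (beyond the scatter) and a number 25 percentage points lower from compound 2 to compound 4 (beyond the scatter), so compound 4 is the lowest of the series so far. This step cannot be read as a clean exchange of one defined configuration for another, and one caveat applies: the fact that one of compounds 3 and 4 is drawn with a defined configuration and the other without, at the place where they differ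

The compounds shown leave open whether the 2-fluorocyclopropyl group responds to the same stereochemical change. They also leave open how a cyclobutyl or 2-hydroxymethylcyclopropyl group on the carbonyl carbon would compare.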